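The compounds below may be only part of what the source reports. "The series", "measured", "known", "first", "only" and "open" are said of these compounds alone.

Among the measured compounds shown here, in a functional assay on SMMC-7721 cells (Homo sapiens) for cytotoxicity, read by MTT assay, with a stated time of 24 h (on this read-out higher numbers stand for weaker inhibition and lower numbers for stronger inhibition), compound 2 `CC(=O)Nc1ccc(S(=O)(=O)N2C/C(=C\c3cccc([N+](=O)[O-])c3)C(=O)/C(=C/c3cccc([N+](=O)[O-])c3)C2)cc1` gives 8420 nM, the highest of the three numbers measured so far, which makes it the weakest inhibitor of the three. Compound 1 `O=C1/C(=C/c2cccc([N+](=O)[O-])c2)CN(S(=O)(=O)c2ccc(F)cc2)C/C1=C\c1cccc([N+](=O)[O-])c1` gives 3980 nM and compound 3 `COc1cc(/C=C2\CN(S(=O)(=O)c3ccc(F)cc3)C/C(=C\c3ccc(C#N)cc3)C2=O)cc(OC)c1OC` gives 4120 nM, and both values lie beyond the scatter from that of compound 2.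

Compound 4 `COc1cc(/C=C2\CN(S(=O)(=O)c3ccc(NC(C)=O)cc3)C/C(=C\c3cccc([N+](=O)[O-])c3)C2=O)cc(OC)c1OC` keeps the acetamido group of compound 2 and differs from it in one place, with 3,4,5-trimethoxyphenyl in place of 3-nitrophenyl on a double-bonded chain carbon bound to a double-bonded ring carbon. For the measured compounds named here, no measured step makes this exact change. Going by the values given here, the one single-place step available is a 2.1-fold higher number from compound 1 to compound 2 (0.33 log units; beyond the scatter), and it is a different change, acetamido in place of fluoro on an aromatic carbon.

Among the compounds with values here, the closest evidence is compound 3, the only measured compound that carries 3,4,5-trimethoxyphenyl, at 4120 nM. It has fluoro rather than acetamido, and it has no 3-nitrophenyl group, so it offers only a weak hint towards a lower number.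

In this assay, the expected result is a small move at most, estimated as a 1.3-fold lower number from compound 2 to compound 4 (0.11 log units; within the scatter), with no clear change beyond the scatter. For compound 4 the estimated value is 6500 nM, with an expected range from 2500 nM to 16000 nM.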

Compound 4, half-maximal inhibitory concentration: 1950 nM
Compound 4: the middle estimate sits 3.3-fold (0.52 log units) above what was measured; the whole stated range lies above it.
By their numbers in this assay, from the lowest: compound 4; then compounds 1 and 3 (each within the scatter of the next); then compound 2.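

In this assay, putting 3,4,5-trimethoxyphenyl in place of 3-nitrophenyl on a double-bonded chain carbon bound to a double-bonded ring carbon gives a 4.3-fold lower number from compound 2 to compound 4 (0.64 log units; beyond the scatter). Among the compounds shown here, this is the first single-place step at this position, and it shows that the number responds to the group held there, while the only earlier step, a 2.1-fold higher number from compound 1 to compound 2 (0.33 log units; beyond the scatter), concerned a different place, the aromatic carbon that carries fluoro or acetamido. Nothing measured here accounts for the new step, so it stands as an observation from a single pair of compounds.

The compounds shown leave open whether the same exchange would give a similar step with fluoro in place of acetamido on the aromatic carbon, a question that needs a matching pair differing only in that exchange. They also leave open how much of the step depends on the full 3,4,5-trimethoxyphenyl group, and whether plain phenyl or a phenyl bearing a single methoxy group at this place would give a number closer to that of compound 2 or to that of compound 4.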